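The source may hold more compounds than are shown below. What is called first, only, known or untested is meant among the compounds shown, and "the series" means these compounds.

Three compounds have been measured in a physicochemical assay for lipophilicity, read by HPLC, measured as chromatographic lipophilicity, at pH 7.4; a lower number here means a more polar compound, a higher number a more lipophilic compound:

Compound 1, `CCCCC(=O)NCCCN1C[C@H](C)C[C@@](C)(O)[C@H](O[C@@H]2O[C@H](C)C[C@H](N(C)C)[C@H]2O)[C@@H](C)[C@H](O[C@H]2C[C@@](C)(OC)[C@@H](O)[C@H](C)O2)[C@@H](C)C(=O)O[C@H](CC)[C@@](C)(O)[C@H](O)[C@H]1C`, gives 2.72.
Compound 2, `CCCCCCCC(=O)NCCCN1C[C@H](C)C[C@@](C)(O)[C@H](O[C@@H]2O[C@H](C)C[C@H](N(C)C)[C@H]2O)[C@@H](C)[C@H](O[C@H]2C[C@@](C)(OC)[C@@H](O)[C@H](C)O2)[C@@H](C)C(=O)O[C@H](CC)[C@@](C)(O)[C@H](O)[C@H]1C`, gives 3.74.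
Compound 3, `CCCCC(=O)NCCCN(C)[C@H]1C[C@@H](C)O[C@@H](O[C@@H]2[C@@H](C)[C@H](O[C@H]3C[C@@](C)(OC)[C@@H](O)[C@H](C)O3)[C@@H](C)C(=O)O[C@H](CC)[C@@](C)(O)[C@H](O)[C@@H](C)N(C)C[C@H](C)C[C@@]2(C)O)[C@@H]1O`, gives 3.08.

Compounds 1 and 2 share one core and differ in a single place: hydrogen in place of propyl on a saturated chain carbon, four bonds along the chain from a carbonyl carbon. This change made a step of a number 1.02 log units lower from compound 2 to compound 1 (beyond the scatter), a large fall that lies well beyond the scatter of this assay. Compound 3 is built on a different core; how its core differs from that of compound 2 is not broken down here. Its value in this assay is the second highest of the three, beyond the scatter from both compound 1 and compound 2.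

Compound 4, `CC[C@H]1OC(=O)[C@H](C)[C@@H](O[C@H]2C[C@@](C)(OC)[C@@H](O)[C@H](C)O2)[C@H](C)[C@@H](O[C@@H]2O[C@H](C)C[C@H](N(C)CCCNC(C)=O)[C@H]2O)[C@](C)(O)C[C@@H](C)CN(C)[C@H](C)[C@@H](O)[C@]1(C)O`, has not yet been measured. It derives from compound 3 by hydrogen in place of propyl on a saturated chain carbon bound to a carbonyl carbon. Going by the values given here, this is the same kind of change as the one from compound 2 to compound 1, though not the same: in compound 4 the place is on a saturated chain carbon bound to a carbonyl carbon, whereas between compound 2 and compound 1 it was on a saturated chain carbon four bonds along the chain from a carbonyl carbon. Given the size of the step seen in a number 1.02 log units lower from compound 2 to compound 1 (beyond the scatter), the step from compound 3 to compound 4 is expected to be of a similar size, about a number 0.98 log units lower from compound 3 to compound 4 (beyond the scatter). Compound 4 is therefore estimated at 2.1, most likely between 1.7 and 2.5.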

Compound 4, distribution coefficient: 2.06
The estimate for compound 4 lay 0.04 log units above the measured number, within the range that was stated.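

In this assay the new step is a number 1.02 log units lower from compound 3 to compound 4 (beyond the scatter) and it has the same size as the earlier step of a number 1.02 log units lower from compound 2 to compound 1 (beyond the scatter) on the other core, so hydrogen in place of propyl lowered the number by the same amount on both cores, even though the place was not the same: on a saturated chain carbon bound to a carbonyl carbon in the new step, and four bonds along the chain from a carbonyl carbon in the earlier one. Going by these compounds alone, this agreement rests on only two pairs of compounds, one per core, so it shows that the change carried over once, not that it would carry over to every core, chain or place. Nothing supplied here explains why the two steps match, and that match may or may not have a single cause.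

The compounds shown leave open whether the step would keep this size if the same change were made at the other place on each core, where only one place has been read per core. They also leave open what would happen if the chain ended in an amine or a carboxylic acid, or if a longer chain stood in its place on the core of compound 3.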